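The compounds below may be only part of what the source reports. "The series", "measured", "known", "first", "only" and "open" are said of these compounds alone.

Compound 3 `C=CCSc1nnc(-c2cc(OC)c(OC)c(OC)c2)n1N1C(=O)c2ccccc2C1=O` carries a vinyl group on a saturated chain carbon bound to a sulfur. In a functional assay on PC-3M cells (Homo sapiens) for cytotoxicity, read by MTT assay, with a stated time of 48 h (on this read-out lower numbers stand for stronger inhibition and higher numbers for weaker inhibition), compound 3 gives only a limit, > 200000 nM, which is not a measured number. The two other measured compounds stand in the same place. Compound 1 `Cc1nnc(SCC(=O)c2ccc(Cl)cc2)n1N1C(=O)c2ccccc2C1=O` also reaches only the limit in this assay, at > 200000 nM. Compound 2 `CSc1nnc(C)n1N1C(=O)c2ccccc2C1=O` likewise stops at the limit of this assay, > 200000 nM. Because of the limit of > 200000 nM in this assay, at which 3 of the 3 values shown sit, none of the three shows a readable potency. The step from compound 1 to compound 2 is a step that the two limits leave unreadable from compound 1 to compound 2, so even the exchange of a (4-chlorophenyl)carbonyl for hydrogen at that place stays hidden.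

Compound 4 `COc1ccc(C(=O)CSc2nnc(-c3cc(OC)c(OC)c(OC)c3)n2N2C(=O)c3ccccc3C2=O)cc1` arises from compound 3 by one change: (4-methoxyphenyl)carbonyl in place of vinyl on a saturated chain carbon bound to a sulfur. Among the compounds with values here, no measured step reads out, so nothing points to a direction. Compound 1 carries a related (4-chlorophenyl)carbonyl at this place and reaches only the limit, > 200000 nM, so compound 4 is expected to stay at the limit as well. The expected step from compound 3 to compound 4 is therefore a step that the limit leaves unreadable from compound 3 to compound 4, nothing beyond the scatter. For compound 4 the estimate in this assay is 300000 nM, between 100000 nM and 1000000 nM.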

Compound 4, half-maximal inhibitory concentration: 32800 nM
Estimate against measurement, compound 4: 9.1-fold (0.96 log units) above; measured number outside the range, below it.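

At the saturated chain carbon bound to a sulfur, the exchange of vinyl for (4-methoxyphenyl)carbonyl gives in this assay an at least 6.0-fold lower number from compound 3 to compound 4 (0.78 log units; beyond the scatter), the only readable step among the compounds shown. This shows that the group at this place can move the result on the shared core, and that a larger group containing an aromatic ring and a carbonyl is accepted here with stronger inhibition rather than a loss of it. The true size of the step stays unknown because its starting point is only a limit and not a number: the limit of > 200000 nM in this assay, at which 3 of the 4 values shown sit.

Within the data shown here, the single step cannot tell whether the change comes from the carbonyl, the aromatic ring or the methoxy group, since all three enter together, and the different groups elsewhere on compound 1 and compound 4 keep those two compounds from settling the matter. It also leaves open how this place would respond to an amine or a carboxylic acid on that ring, or to a longer chain between the sulfur and the carbonyl.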